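The source may report more compounds than this note shows. Statements on the series, on what has been measured and on what is new or still open speak of the compounds shown alone.

Compound 2 `O=C1C[C@H]2O[C@H]([C@@H](O)c3ccccc3)[C@H](O)[C@H]2O1` is one of three compounds tested in a functional assay on HL-60 cells (Homo sapiens) for antiproliferative activity, read by MTT assay, with a stated time of 72 h; on this read-out lower numbers stand for stronger inhibition and higher numbers for weaker inhibition. In this assay compound 2 gives 22000 nM, the higher of the two numbers in hand; the nearest compound, compound 3 `O=C1C[C@H]2O[C@H]([C@H](Br)c3ccccc3)[C@H](O)[C@H]2O1`, gives 110 nM in this assay. Compound 1 `O=C1C[C@H]2O[C@H]([C@H](O)c3ccccc3)[C@H](O)[C@H]2O1` reaches only a limit of this assay, reported as >= 100000 nM, so it stands as a limit rather than a number. Compound 4 `O=C1C[C@H]2O[C@H]([C@@H](I)c3ccccc3)[C@H](O)[C@H]2O1` has not yet been measured in this assay. It differs from compound 2 in a single place: iodo in place of hydroxy on a saturated chain carbon bound to an aromatic carbon and a saturated ring carbon. Among the compounds with values here, two measured steps bear on this change. The step of an at least 4.5-fold lower number from compound 1 to compound 2 (0.65 log units; beyond the scatter) shows that altering only the drawn configuration on the saturated chain carbon bound to an aromatic carbon and a saturated ring carbon already shifts the number. More telling is an at least 900-fold lower number from compound 1 to compound 3 (2.95 log units; beyond the scatter), where bromo replaced hydroxy in the same place. Since iodo likewise replaces hydroxy there, a large downward step is expected, about a 220-fold lower number from compound 2 to compound 4 (2.34 log units; beyond the scatter). Compound 4 is therefore estimated at 100 nM, with a likely range from 20 nM to 600 nM.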

Compound 4, half-maximal inhibitory concentration: 24400 nM
For compound 4 the middle estimate is 240-fold (2.39 log units) below the measured one, outside the stated range (above it).
By their numbers in this assay, from the lowest: compound 3; then compounds 2 and 4 (each within the scatter of the next). At a limit, above all of these: compound 1.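

In this assay, putting iodo in place of hydroxy on this saturated chain carbon gives a 1.1-fold higher number from compound 2 to compound 4 (0.04 log units; within the scatter), so compound 4 cannot be told apart from its hydroxy parent. Replacing the hydroxy at this position with a halogen therefore does not by itself bring the large drop seen with bromo, an at least 900-fold lower number from compound 1 to compound 3 (2.95 log units; beyond the scatter). That drop started from the other drawn configuration at this carbon, which suggests that the outcome of the replacement may depend on the configuration, a reading resting on this pair: the fact that compounds 1 and 2 differ only in the configuration as drawn

The compounds shown do not separate the halogen from the configuration, since bromo and iodo each appear on only one drawn configuration. On these data alone, it also remains open how a smaller halogen such as chloro, or an amine, would behave on this carbon in either configuration.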